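Vinyl Replaces Cyclohexylmethyl on a Benzylated Sugar Core

The source may report more compounds than this note shows. Statements on the series, on what has been measured and on what is new or still open speak of the compounds shown alone.

Compound 1 `O[C@@H]1[C@@H](OCc2ccccc2)[C@H](OCc2ccccc2)[C@@H](COCc2ccccc2)O[C@@H]1CC1CCCCC1`: 17200 nM
Compound 2 `O[C@@H]1[C@@H](OCc2ccccc2)[C@H](OCc2ccccc2)[C@@H](COCc2ccccc2)O[C@H]1CC1CCCCC1`: 4100 nM

Among the compounds with values here, in a functional assay on HL-60 cells (Homo sapiens) for antiproliferative activity, read by MTT assay (a higher number here means a weaker inhibitor, a lower number a stronger inhibitor), compound 2 gives 4100 nM, the lowest of the two numbers known, and the only measured step is a 4.2-fold lower number from compound 1 to compound 2 (0.62 log units; beyond the scatter), which rests on the fact that compounds 1 and 2 differ only in the configuration as drawn alone. Compound 3 `C=C[C@@H]1O[C@H](COCc2ccccc2)[C@@H](OCc2ccccc2)[C@H](OCc2ccccc2)[C@H]1O` differs from compound 2 by vinyl in place of cyclohexylmethyl on a saturated ring carbon. Within the data shown here, no measured step swaps one group for another, so that step gives no guide to the size or direction of this change, and the expectation must stay wide. Compound 3 is estimated at 9000 nM, between 2500 nM and 35000 nM, meaning an expected 2.2-fold higher number from compound 2 to compound 3 (0.34 log units; beyond the scatter).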

Compound 3, half-maximal inhibitory concentration: 11800 nM
For compound 3 the middle estimate is 1.3-fold (0.12 log units) below the measured one, and the stated range covers the measured number.
By their numbers in this assay, from the lowest: compound 2; then compounds 3 and 1 (each within the scatter of the next).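

In this assay, within the data shown here, this is the first measured exchange of one group for another on this saturated ring carbon next to the ring oxygen, and vinyl in place of cyclohexylmethyl gives a modest loss (a 2.9-fold higher number from compound 2 to compound 3 (0.46 log units; beyond the scatter)). The number at this position therefore depends on the group it carries, not only on configuration as drawn. Nothing at hand explains this step.

Going by these compounds, whether an amine, a carboxylic acid or a longer chain here would give a lower number stays open. So does whether reversing the configuration at this carbon would matter with vinyl.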